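The compounds below may be only part of what the source reports. "The series", "measured", "known", "first", "only" and "open" are said of these compounds alone.

In a functional assay with Oryctolagus cuniculus as the target (a lower number here means a stronger inhibitor, a higher number a weaker inhibitor), compound 1 (`COc1ccc(-c2nc(/N=C(\N)N(C)C)sc2-c2ccc(OC)cc2)cc1`) gives 37 nM and compound 2 (`COc1ccc(-c2nc(CN(C)C)sc2-c2ccc(OC)cc2)cc1`) gives 96 nM as the higher of the two numbers. Compound 3 (`COc1ccc(-c2nc(CN)sc2-c2ccc(OC)cc2)cc1`) differs from compound 2 by amino in place of dimethylamino on a saturated chain carbon bound to an aromatic carbon. Within the data shown here, the only measured step, a 2.6-fold higher number from compound 1 to compound 2 (0.41 log units; beyond the scatter), is modest and concerns a group on an aromatic carbon, so it bears only loosely on this change. In this assay, among the measured compounds shown here, no step clearly beyond the scatter is expected, with a slight lean towards a higher number. The expected step is a 1.3-fold higher number from compound 2 to compound 3 (0.10 log units; within the scatter) as a working figure. Compound 3 is estimated at 120 nM within an expected range of 35 nM to 400 nM for now.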

Compound 3, half-maximal inhibitory concentration: > 100 nM
Compound 3: only a limit was reported; the forecaster's own chance of this, stated with the estimate: 3%; the middle value does not contradict the limit.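

In this assay compound 3 gives > 100 nM, a limit of the assay and not a number. Amino in place of dimethylamino therefore reads only as an at least 1.0-fold higher number from compound 2 to compound 3 (0.01 log units; that floor lies within the scatter), so this change has no fixed size and may be anything from no real shift to a large loss. The group change at the aromatic carbon reads as an at least 2.7-fold higher number from compound 1 to compound 3 (0.43 log units; beyond the scatter), so aminomethyl, like (dimethylamino)methyl, gives a higher number than the group in compound 1.

On these data alone, the true value of compound 3 remains open. So does the effect of a methylamino group or a carboxylic acid on the saturated chain carbon bound to an aromatic carbon.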